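Methyl to Methoxy on the Aryl Tail

The compounds below may be only part of what the source reports. "The series", "measured", "known", "first", "only" and "open" are said of these compounds alone.

Going by the values given here, compound 2 `Cc1ccc(-c2ccnc(C(=O)Nc3ccc(Oc4ccnc5[nH]ccc45)c(F)c3)n2)cc1` gives 1150 nM in a functional assay on A549 cells (Homo sapiens) for cytotoxicity, read by MTT assay, with a stated time of 72 h (a lower number here means a stronger inhibitor, a higher number a weaker inhibitor), the lower of the two numbers measured so far. Among the compounds with values here, its only neighbor, compound 1 `Cc1ccc(-c2ccnc(C(=O)Nc3ccc(Oc4ccnc5[nH]ccc45)cc3)n2)cc1`, gives 2380 nM in this assay, and the single measured step, a 2.1-fold lower number from compound 1 to compound 2 (0.32 log units; beyond the scatter), is the one change yet seen. Compound 3 `COc1ccc(-c2ccnc(C(=O)Nc3ccc(Oc4ccnc5[nH]ccc45)c(F)c3)n2)cc1` differs from compound 2 by methoxy in place of methyl on an aromatic carbon. Within the data shown here, no measured step bears on this change: the fluoro step concerns a different group at a different place, so it offers no direction for the present one. With nothing in the measured steps pointing either way, a 1.0-fold higher number from compound 2 to compound 3 (0.02 log units; within the scatter) is expected to stay within the scatter. Compound 3 is therefore estimated at 1200 nM in this assay, with a range from 500 nM to 3000 nM to allow for the uncertainty of an untested change.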

Compound 3, half-maximal inhibitory concentration: 5430 nM
Compound 3: middle estimate off by 4.5-fold (0.66 log units), on the low side; the whole stated range lies below it.
By their numbers in this assay, from the lowest: compound 2; then compound 1; then compound 3.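

The change from 4-methylphenyl to 4-methoxyphenyl gives a 4.7-fold higher number from compound 2 to compound 3 (0.67 log units; beyond the scatter) in this assay, so this place on the aromatic ring, para to a large group, is not indifferent to what it carries. The step runs in the opposite direction to a 2.1-fold lower number from compound 1 to compound 2 (0.32 log units; beyond the scatter), which came from a change at a different place, and compound 2 keeps the lowest number of the three while compound 3 takes the highest. No measurement at hand accounts for the higher number of compound 3.

The compounds shown leave open whether an ethyl, a chloro or an amine at this same place would stay close to compound 2 or move toward compound 3. They also leave open whether methoxy in place of methyl would move the number the same way on a compound without the fluoro group of compound 2.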